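A few compounds are considered here, and "the series" means these few. Any claim that something is new, unique, unknown or untested is made for them only; others in the source may bear on it.

Among the compounds with values here, compound 2 `O=C(N/N=C/c1ccc(O)cc1)c1cccnc1Nc1cccc(C(F)(F)F)c1` gives the higher number of the two compounds measured so far in a functional assay on the whole organism (strain Wistar) for inhibition, with Rattus norvegicus as the target, read by paw edema, with a stated time of 4 h, at a dose of 10 mg/kg by the intraperitoneal route; a higher number here means more inhibition at the dose given (going by the name of the read-out), a lower number less inhibition: compound 2 gives 61.6%, while compound 1 `O=C(N/N=C/c1ccc(Cl)cc1)c1cccnc1Nc1cccc(C(F)(F)F)c1` gives 43.7%. Within the data shown here, the one step between them, a number 17.9 percentage points higher from compound 1 to compound 2 (beyond the scatter), is the only comparison available here.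

Compound 3 `COc1ccc(/C=N/NC(=O)c2cccnc2Nc2cccc(C(F)(F)F)c2)c(OC)c1` has not been measured yet. It differs from compound 2 in one place: 2,4-dimethoxyphenyl in place of 4-hydroxyphenyl on a carbon with a double bond to nitrogen. The entering group carries no hydrogen-bond donor and two hydrogen-bond acceptors, where the leaving group had one of each. Among the measured compounds shown here, the step from compound 1 to compound 2 bears on this only loosely: it shows that a hydroxy on that ring gave a modestly higher number than a chloro, but no measured compound carries a methoxy, and none carries two groups on that ring. The hydroxy that went with the higher number is lost in compound 3, so the number is expected to sit somewhat lower than that of compound 2, with a number 11.6 percentage points lower from compound 2 to compound 3 (beyond the scatter) as the expected step. Compound 3 is therefore estimated at 50% in this assay, within a range from 35% to 65%.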

Compound 3, a percentage reported as inhibition, in the whole organism at one dose (the size of the read-out at that dose, not a potency): 19.8%
Beside the measured number, compound 3's estimate is 30.2 percentage points above it; measured number below the stated range.
By their numbers in this assay, from the lowest: compound 3; then compound 1; then compound 2.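

In this assay the step from 4-hydroxyphenyl to 2,4-dimethoxyphenyl on the carbon with a double bond to nitrogen is a number 41.8 percentage points lower from compound 2 to compound 3 (beyond the scatter), a large step where the earlier chloro-to-hydroxy change was only modest. So the group at this place can move the number much further than the first two compounds showed, and here the change takes it down. The comparison with the chloro compound, a number 23.9 percentage points lower from compound 1 to compound 3 (beyond the scatter), adds that losing the hydroxy cannot be the whole story, since compound 1 also has no hydroxy yet stands well above compound 3, and nothing available here accounts for the drop.

The change to compound 3 removes the hydroxy and brings in two methoxy groups at once, so the compounds shown cannot separate the effect of either methoxy from that of the other or from the loss of the hydroxy. A ring with a single methoxy would help to separate them, and an amine on the ring would show whether a group other than hydroxy can go with a higher number.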